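A few compounds are considered here, and "the series" means these few. Any claim that something is new, unique, unknown or untested is made for them only; others in the source may bear on it.

Measured in a functional assay, read by spectrophotometry, with a stated time of 15 min; a lower number here means a stronger inhibitor, a higher number a weaker inhibitor:
compound 1 `Cc1nc2c3ccccc3ccc2c2nc3c(ccc4ccccc43)c(-c3ccccc3Cl)c12` gives 74.6 ug/mL
compound 2 `Cc1nc2c3ccccc3ccc2c2nc3c(ccc4ccccc43)c(-c3nccnc3N)c12` gives 47.8 ug/mL
compound 3 `COc1ccc(-c2c3ccc4ccccc4c3nc3c2c(C)nc2c4ccccc4ccc32)cc1` gives 82.3 ug/mL

Compound 1 stands second highest of the three numbers; compound 3 is nearest, and the gap to compound 2 also lies within the scatter. Compound 4 `Cc1nc2c3ccccc3ccc2c2nc3c(ccc4ccccc43)c(-c3ccc(O)cc3)c12` differs from compound 1 in one place: 4-hydroxyphenyl in place of 2-chlorophenyl on an aromatic carbon The measured step that bears most directly on this is the exchange on the same aromatic carbon, a 1.1-fold higher number from compound 1 to compound 3 (0.04 log units; within the scatter), within the scatter. The other exchanges there, a 1.6-fold lower number from compound 1 to compound 2 (0.19 log units; within the scatter) and a 1.7-fold higher number from compound 2 to compound 3 (0.24 log units; within the scatter), are likewise within the scatter. Three different groups on this aromatic carbon have left the number essentially unmoved, so no step beyond the scatter is expected for compound 4 in this assay; the expected step is a 1.0-fold lower number from compound 1 to compound 4 (0.02 log units; within the scatter). Compound 4 is estimated at 72 ug/mL, with a range of 40 ug/mL to 130 ug/mL.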

Compound 4, half-maximal inhibitory concentration: 44.1 ug/mL
Compound 4: the middle estimate sits 1.6-fold (0.21 log units) above what was measured; low and high end bracket the measured number.
By their numbers in this assay, from the lowest: compounds 4, 2, 1 and 3 (each within the scatter of the next).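

In this assay, 4-hydroxyphenyl on this aromatic carbon, opposite the ring nitrogen, stays within the scatter of both 2-chlorophenyl (a 1.7-fold lower number from compound 1 to compound 4 (0.23 log units; within the scatter)) and 3-aminopyrazin-2-yl (a 1.1-fold lower number from compound 2 to compound 4 (0.03 log units; within the scatter)). The first change made on the phenyl substituent itself, hydrogen in place of methyl on the oxygen, also stays within the scatter (a 1.9-fold lower number from compound 3 to compound 4 (0.27 log units; within the scatter)). No evidence on hand accounts for these numbers.

Going by these compounds, whether a carboxylic acid, an aminomethyl group or a longer alkoxy chain on the phenyl ring would step beyond the scatter stays open. So does the effect of replacing the methyl on the shared core.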